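The compounds below may be only part of what the source reports. "The series", "measured", "known", "first", "only" and "open" are said of these compounds alone.

Working notes on the diaryl urea series sharing the core of compound 1 `O=C(Nc1ccc(Cl)cc1)Nc1ccc(Oc2ccc(-c3nccs3)cc2)cc1`. In a functional assay on A549 cells (Homo sapiens) for inhibition, read by MTT assay and WST assay, with a stated time of 72 h, tested at 10 uM (on this read-out lower numbers stand for less inhibition of growth and higher numbers for more inhibition of growth at the one concentration tested), compound 1 gives 17.7%. Compound 2 `O=C(Nc1ccc(Oc2ccc(-c3nccs3)cc2)cc1)Nc1ccc(Cl)c([N+](=O)[O-])c1` gives 77.1%, and compound 3 `O=C(Nc1ccc(Oc2ccc(-c3nccs3)cc2)cc1)Nc1cc(C(F)(F)F)ccc1Cl` gives 75.5%, which places compound 3 second highest of the three numbers, with compound 2 nearest and compound 1 furthest.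

The step to compound 4 `CC(=O)Oc1sccc1NC(=O)Nc1ccc(Oc2ccc(-c3nccs3)cc2)cc1` is 2-acetoxythiophen-3-yl in place of 2-chloro-5-(trifluoromethyl)phenyl on an amide-type nitrogen. Two measured steps change the same aryl group on the amide-type nitrogen: a number 57.8 percentage points higher from compound 1 to compound 3 (beyond the scatter) and a number 1.6 percentage points lower from compound 2 to compound 3 (within the scatter). So one exchange at this nitrogen moved the number by a large amount, another did not move it beyond the scatter; the 2-acetoxythiophen-3-yl group entering here has no measured precedent in the series. The expected step of a number 30.5 percentage points lower from compound 3 to compound 4 (beyond the scatter) is therefore uncertain in direction, with a drop considered possible given the low value of compound 1 17.7% against an unsubstituted aryl.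

Compound 4 is estimated at 45% in this assay, in a range from 10% to 80%.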

Compound 4, percent growth inhibition at one concentration: 6.78%
Compound 4: the middle estimate sits 38.2 percentage points above what was measured; measured number below the stated range.
By their numbers in this assay, from the lowest: compound 4; then compound 1; then compounds 3 and 2 (each within the scatter of the next).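

In this assay the entry of 2-acetoxythiophen-3-yl on the amide-type nitrogen gives a number 68.7 percentage points lower from compound 3 to compound 4 (beyond the scatter) and a number 70.3 percentage points lower from compound 2 to compound 4 (beyond the scatter) so the high values of the two substituted phenyl compounds do not carry over to this group. The further step a number 10.9 percentage points lower from compound 1 to compound 4 (beyond the scatter) shows that exchange at this nitrogen can reach below the low value held by the 4-chlorophenyl group, which leaves compound 4 the lowest of the four. No measured evidence accounts for this drop.

The five-membered aromatic ring and the acetoxy group enter together, so the shown compounds do not separate their contributions. Open, on these data alone, are a plain thiophen-3-yl group and thiophenes with an amine or a carboxylic acid in place of the acetoxy group.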